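Pentyloxy for cyclopropylamino on the shared core

The source may report more compounds than this note shows. Statements on the series, on what has been measured and on what is new or still open speak of the compounds shown alone.

Compound 1 `Nc1nc(NCc2ccccc2)c2ncn(/C=C3/CC3(CO)CO)c2n1`, compound 2 `Nc1nc(NC2CC2)c2ncn(/C=C3/CC3(CO)CO)c2n1` and compound 3 `Nc1nc2c(ncn2/C=C2/CC2(CO)CO)c(=O)[nH]1` share one core. In an ADME assay on MOLT-3 cells (Homo sapiens) for cytotoxicity, with a stated time of 7 days (a lower number here means that less compound is tolerated, a higher number that more compound is tolerated), compound 1 reaches only a limit of the assay, > 20000 nM. In this assay compound 2 likewise gives only a limit, > 20000 nM. In this assay compound 3 also stops at a limit, > 20000 nM. Within the data shown here, the single measured step, cyclopropyl in place of benzyl on a nitrogen on an aromatic ring, is a step that the two limits leave unreadable from compound 1 to compound 2 because of the limit of > 20000 nM in this assay, at which 3 of the 3 values shown sit. Compound 4 `CCCCCOc1nc(N)nc2c1ncn2/C=C1/CC1(CO)CO` is not yet measured; it differs from compound 2 by pentyloxy in place of cyclopropylamino on an aromatic carbon. Among the measured compounds shown here, no measured step covers this change and no measured value is a number, so compound 4 is expected to stay at the limit as well, a step from compound 2 of a step that the limit leaves unreadable from compound 2 to compound 4. Compound 4 is therefore estimated at 30000 nM, between 15000 nM and 100000 nM.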

Compound 4, half-maximal cytotoxic concentration: > 20000 nM
Compound 4 was reported as a limit (the forecaster's own chance of this, stated with the estimate: 85%); the middle value does not contradict the limit.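

No step from compound 1 or compound 2 to compound 4 can be read, because these compounds stop at one limit: the limit of > 20000 nM in this assay, at which 4 of the 4 values shown sit.

The compounds shown leave open whether pentyloxy, cyclopropylamino and benzylamino differ at all in this assay.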